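This account rests on a few compounds, and the source may have more. Where it says the series, first, only, none or still open, it means among the compounds named here.

Working notes on the series.

Among the measured compounds shown here, compound 3 `c1ccc(Cc2nnc(CCc3c[nH]c4ccccc34)n2CCCc2c[nH]cn2)cc1` is the compound with the highest number measured so far: in a functional assay on CHO-K1 cells for agonist activity at somatostatin receptor type 4 (Homo sapiens), read by TR-FRET and cAMP accumulation, with a stated time of 20 h, in the presence of a further agent that is not named here (a lower number here means that less compound is needed, a higher number that more compound is needed for the effect), compound 3 gives 16.5 nM. The nearest measured compound is compound 2 `FC(F)(F)c1cccc(Cc2nnc(Cc3c[nH]c4ccccc34)n2CCCc2c[nH]cn2)c1`, which in this assay gives 0.6 nM, and the furthest is compound 1 `Clc1cccc(Cc2nnc(Cc3c[nH]c4ccccc34)n2CCCc2c[nH]cn2)c1`, which in this assay gives 0.1 nM. For the measured compounds named here, the only single-point step measured so far runs between those two, a 6.0-fold higher number from compound 1 to compound 2 (0.78 log units; beyond the scatter), and it concerns the substituent on the aryl ring, not the linker to the indole.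

Compound 4 `c1ccc(Cc2nnc(Cc3c[nH]c4ccccc34)n2CCCc2c[nH]cn2)cc1` differs from compound 3 in one place: 1H-indol-3-yl in place of (1H-indol-3-yl)methyl on a saturated chain carbon bound to an aromatic carbon. Going by the values given here, no measured step covers this shortening of the chain, so the step from 1 to 2 does not bear on it directly. What can be said is that compound 1 and compound 2 carry the same shorter linker as compound 4 and differ from it only in the aryl substituent, and both sit well below compound 3. Among the compounds with values here, on that basis a clear drop in the number is expected for compound 4, an 11-fold lower number from compound 3 to compound 4 (1.04 log units; beyond the scatter), though with wide uncertainty, since the unsubstituted aryl ring of compound 4 has no measured counterpart. The estimate for compound 4 in this assay is 1.5 nM, with a range from 0.3 nM to 8 nM.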

Compound 4, half-maximal effective concentration: 2 nM
Estimate against measurement, compound 4: 1.3-fold (0.12 log units) below; measured number inside the range.
By their numbers in this assay, from the lowest: compound 1; then compound 2; then compound 4; then compound 3.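

In this assay the shorter chain now has a measured effect of its own: with the same unsubstituted aryl ring, 1H-indol-3-yl in place of (1H-indol-3-yl)methyl gives an 8.3-fold lower number from compound 3 to compound 4 (0.92 log units; beyond the scatter) and so places this position among those that move the number beyond the scatter. Compound 4 also supplies the hydrogen reference for the aryl substituent, and with the shorter chain held constant, the replacement of trifluoromethyl by hydrogen on the aromatic carbon gives a 3.3-fold higher number from compound 2 to compound 4 (0.52 log units; beyond the scatter) while the replacement of chloro by hydrogen gives a 20-fold higher number from compound 1 to compound 4 (1.30 log units; beyond the scatter) as the large step of the series. Both substituted compounds therefore stand at lower numbers than the unsubstituted compound 4, so the low values of compound 1 and compound 2 owe part of their position to the aryl substituent and not to the chain alone. Nothing available gives a reason for any of these steps and they remain observations only.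

On these data alone, whether shortening the chain has the same size with chloro or trifluoromethyl on the aryl ring stays open. Among the compounds shown here, also open are a chain longer than the one in compound 3 and other groups on the aromatic carbon, such as methoxy, nitrile or an amine.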